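The source may report more compounds than this note shows. Statements on the series, on what has been measured and on what is new or still open speak of the compounds shown alone.

Of the compounds shown here, two of one shared core have been measured in a functional assay on HepG2 cells (Homo sapiens) for inhibition, read by MTT assay, with a stated time of 24 h; a lower number here means a stronger inhibitor, a higher number a weaker inhibitor. Compound 1 `CC1(C)[C@H]2CC[C@]1(C)N(Cc1cn(-c3ccccc3C#N)nn1)C(=O)C2` gives 180 nM, and compound 2 `CC1(C)[C@H]2CC[C@]1(C)N(Cc1cn(-c3cccc(Cl)c3)nn1)C(=O)C2` gives 60 nM. Within the data shown here, the single comparison between them, a 3.0-fold lower number from compound 1 to compound 2 (0.48 log units; beyond the scatter), came with the change to 3-chlorophenyl in place of 2-cyanophenyl on an aromatic nitrogen. On the two numbers available, compound 2 stands lowest, with compound 1 the nearest and higher.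

Compound 3 `COc1ccc(-n2cc(CN3C(=O)C[C@@H]4CC[C@@]3(C)C4(C)C)nn2)cc1` is not yet measured. It differs from compound 2 as follows: 4-methoxyphenyl in place of 3-chlorophenyl on an aromatic nitrogen. Among the measured compounds shown here, the one step seen so far, a 3.0-fold lower number from compound 1 to compound 2 (0.48 log units; beyond the scatter), shows that swapping the group on this aromatic nitrogen can move the number modestly, but it involved different groups, so it gives only a loose guide to the present change. For the measured compounds named here, no measured pair shows a 4-methoxyphenyl at this position. The step is therefore expected to be small, if anything a slight rise, as a 2.0-fold higher number from compound 2 to compound 3 (0.30 log units; within the scatter). For compound 3 in this assay the estimated value is 120 nM, with a range from 40 nM to 400 nM.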

Compound 3, half-maximal inhibitory concentration: 100 nM
Estimate against measurement, compound 3: 1.2-fold (0.08 log units) above, and the stated range covers the measured number.
By their numbers in this assay, from the lowest: compounds 2, 3 and 1 (each within the scatter of the next, the first and the last beyond it).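

In this assay the change to 4-methoxyphenyl in place of 3-chlorophenyl gives a 1.7-fold higher number from compound 2 to compound 3 (0.22 log units; within the scatter) and so cannot be told apart from repeat measurement, even though the entering group differs in its atoms and in the place of its substituent on the phenyl ring. The change to 4-methoxyphenyl in place of 2-cyanophenyl gives a 1.8-fold lower number from compound 1 to compound 3 (0.26 log units; within the scatter) and is equally unresolved, so compound 3 cannot be separated from either neighbour, although compound 1 and compound 2 are separated from each other, and this position has now accepted three differently substituted phenyl groups with only a modest spread in the numbers. Among these compounds, nothing at hand explains these steps or the one separated pair.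

The compounds shown leave open how much depends on the substituent itself and how much on its place on the ring, which 3-methoxyphenyl and 4-chlorophenyl would help to separate. They also leave open how the number responds to a plain phenyl, or to a ring carrying an amine or a carboxylic acid, at this aromatic nitrogen.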